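The compounds below may be only part of what the source reports. "The series", "measured", "known", "first", "only" and "open" are said of these compounds alone.

Working notes on the series. In a functional assay on DU-145 cells (Homo sapiens) for inhibition, read by trypan blue exclusion, with a stated time of 96 h (on this read-out lower numbers stand for stronger inhibition of growth and higher numbers for weaker inhibition of growth), compound 1 (`O=C(/C(=C\c1ccc(Cl)cc1Cl)S(=O)(=O)c1ccc(Br)cc1)c1ccc(Cl)cc1`) gives 50000 nM. Compound 3 (`Cc1ccc(S(=O)(=O)/C(=C/c2sccc2C)C(=O)c2ccc(Br)cc2)cc1`) gives 25000 nM, within the scatter of compound 1, so the two share the high end of the three numbers. Compound 2 (`O=C(/C(=C\c1ccc(Br)cc1)Sc1ccc(Br)cc1)c1ccc(Br)cc1`) gives 1000 nM, a much lower number and beyond the scatter from compound 1. Compound 1 therefore stands at the weak end of the measured range, level with compound 3 within the scatter.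

The next compound is compound 4 (`COc1ccc(/C=C(\C(=O)c2ccc(Cl)cc2)S(=O)(=O)c2ccc(Br)cc2)cc1O`), not yet measured. Its difference from compound 1 is 3-hydroxy-4-methoxyphenyl in place of 2,4-dichlorophenyl on a double-bonded chain carbon bound to a double-bonded chain carbon. In words, this is 3-hydroxy-4-methoxyphenyl in place of 2,4-dichlorophenyl on a double-bonded chain carbon bound to a double-bonded chain carbon.

Within the data shown here, no measured pair differs in one place only, so nothing measured sizes this swap directly. Compound 2 and compound 3 each differ from compound 1 in more than one place. Among the measured compounds shown here, the only guide is the measured spread, from compound 2 at 1000 nM to compound 1 at 50000 nM. A moderate move towards stronger inhibition of growth, inside that spread, is expected in this assay, with wide uncertainty. The expected step is a 10-fold lower number from compound 1 to compound 4 (1.00 log units; beyond the scatter). Compound 4 is estimated at 5000 nM, with an expected range of 800 nM to 30000 nM.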

Compound 4, concentration for 50% growth inhibition: 10000 nM
Estimate against measurement, compound 4: 2.0-fold (0.30 log units) below, within the range that was stated.
By their numbers in this assay, from the lowest: compound 2; then compound 4; then compounds 3 and 1 (each within the scatter of the next).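

Among these compounds, the swap gives a 5.0-fold lower number from compound 1 to compound 4 (0.70 log units; beyond the scatter) in this assay, and this is the first sized change with the rest of the molecule held fixed. It shows that this place, on a double-bonded chain carbon bound to a double-bonded chain carbon, is not silent on this read-out: replacing 2,4-dichlorophenyl, with 0 hydrogen-bond donors and 0 hydrogen-bond acceptors, by 3-hydroxy-4-methoxyphenyl, with 1 hydrogen-bond donor and 2 hydrogen-bond acceptors, moves the number towards stronger inhibition of growth by a step beyond the scatter. No measured information on the compounds accounts for this step, so it stands as an observation on one pair only.

From the compounds shown here alone, it remains open whether the hydroxy, the methoxy or the loss of the two chlorines carries the step, as this single swap changes all of them together. Equally open, going by these compounds, is how the number responds at this place to a phenyl ring carrying an amine or a carboxylic acid, and whether the same swap gives a step of similar size on the other compounds.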